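The compounds below may be only part of what the source reports. "The series", "measured", "known", "first", "only" and "open" are said of these compounds alone.

Working notes on the series. Two compounds have numbers in a physicochemical assay for lipophilicity, in phosphate buffer, measured as octanol-water partition, with a stated time of 24 h (on this read-out higher numbers stand for higher lipophilicity and lower numbers for lower lipophilicity), so far: compound 1 `Cc1ccc(Oc2ccc(/C=N/NC(=S)Nc3ccc(Cl)cc3)cc2)cc1` gives 5.97, and compound 2 `Cc1ccc(Oc2ccc(/C=N/NC(=S)Nc3ccc(F)cc3)cc2)cc1` gives 5.48. Within the data shown here, the one measured step within the pair, a number 0.49 log units lower from compound 1 to compound 2 (beyond the scatter), came with fluoro in place of chloro on an aromatic carbon. On this basis compound 2 stands lowest of the two numbers, with compound 1 the nearer and higher neighbour beyond the scatter.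

The next compound, compound 3 `Fc1ccc(NC(=S)N/N=C/c2ccc(Oc3ccc(Br)cc3)cc2)cc1`, differs from compound 2 by bromo in place of methyl on an aromatic carbon, para to a large group; cut one bond further out, 4-methylphenoxy becomes 4-bromophenoxy. No measured step covers this exchange: the single step shown, from compound 1 to compound 2, swaps one halogen for another at a different place, so it gives only a sense of scale, not of direction for a methyl-to-bromo swap. The expected step in this assay is therefore a small rise, a number 0.30 log units higher from compound 2 to compound 3 (within the scatter), near the edge of the scatter. Compound 3 is accordingly estimated at 5.78, with a range from 5.4 to 6.2.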

Compound 3, partition coefficient: 5.88
Compound 3: middle estimate off by 0.10 log units, on the low side; the range from low to high includes it.
By their numbers in this assay, from the lowest: compound 2; then compounds 3 and 1 (each within the scatter of the next).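

With 4-bromophenoxy in place of 4-methylphenoxy, on an aromatic carbon para to a large group, this assay gives a number 0.40 log units higher from compound 2 to compound 3 (beyond the scatter). Among these compounds, this is the first reading at this place: the earlier step, a number 0.49 log units lower from compound 1 to compound 2 (beyond the scatter), concerned a halogen exchange at a different place and gave no direction for this one, whereas the number now also moves beyond the scatter when a single bromine replaces a single methyl carbon, with the fluoro group held constant. Nothing available explains the direction or the size of this rise, which stands here as an observation on one matched pair only.

On these data alone, the position is described by this one exchange, so it remains open how an amine, a carboxylic acid, a longer chain or a chloro group at the same place would read in this assay. It also remains open whether bromo in place of methyl gives a similar step when chloro rather than fluoro sits at the other varied place, since the compounds shown contain no such matched pair.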